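The source may hold more compounds than are shown below. What is called first, only, known or untested is meant among the compounds shown, and "the series" means these compounds.

The study compares a short series of compounds that differ in the length of a chain ending in a hydroxy group, and in the core that carries that chain. Compound 1 `NS(=O)(=O)c1ccc(SCCO)c(F)c1` and compound 2 `NS(=O)(=O)c1ccc(SCCCO)c(F)c1` share one core; compound 3 `NS(=O)(=O)c1ccc(SCCCO)s1` and compound 4 `NS(=O)(=O)c1ccc(SCCCCO)s1` share another. The difference between the two cores is not broken down here.

In a physicochemical assay for solubility, at pH 7.4 (a lower number here means a less soluble compound, a higher number a more soluble compound), compound 1 gives 6000 ug/mL, while compound 2 gives 900 ug/mL. The step between them, a 6.7-fold lower number from compound 1 to compound 2 (0.82 log units; beyond the scatter), corresponds to hydroxymethyl in place of hydroxy on a saturated chain carbon, two bonds along the chain from a sulfur.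

Compound 3 gives 9500 ug/mL in this assay. Its number lies within the scatter of compound 1 and beyond the scatter of compound 2. Compound 4 has not yet been measured. It differs from compound 3 by hydroxymethyl in place of hydroxy on a saturated chain carbon, three bonds along the chain from a sulfur. Within the data shown here, this is the same kind of change as the one from compound 1 to compound 2, not the same change: the earlier one sits two bonds along the chain from a sulfur, the new one three bonds along the chain from a sulfur.

Among the measured compounds shown here, a drop of broadly comparable size is expected, a 5.3-fold lower number from compound 3 to compound 4 (0.72 log units; beyond the scatter), because the one measured instance of this kind of change gave a 6.7-fold lower number from compound 1 to compound 2 (0.82 log units; beyond the scatter). Some allowance is made for the different core and the different place along the chain. Compound 4 is therefore estimated at 1800 ug/mL, with a range from 600 ug/mL to 5000 ug/mL.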

Compound 4, solubility: 9300 ug/mL
The estimate for compound 4 lay 5.2-fold (0.71 log units) below the measured number; the whole stated range lies below it.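

In this assay the new step is a 1.0-fold lower number from compound 3 to compound 4 (0.01 log units; within the scatter) and so stays within the scatter, whereas the same kind of change on the other core gave a 6.7-fold lower number from compound 1 to compound 2 (0.82 log units; beyond the scatter) and lay beyond it, which shows that the size of the step seen on the core of compound 1 did not carry over to the core of compound 3. This does not show that the core alone sets the outcome: the step on the core of compound 1 sits two bonds along the chain from a sulfur, the step on the core of compound 3 sits three bonds along the chain from a sulfur, and with one step at each place on each core the two differences cannot be told apart. Nothing available here bears on the reason for the contrast between the two steps.

The compounds shown leave open how a chain ending in an amine or a carboxylic acid in place of the hydroxy group would read on either core. They also leave open whether a longer chain, such as 5-hydroxypentyl, on the core of compound 3 would again give a step within the scatter.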